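A few compounds are considered here, and "the series" means these few. Any claim that something is new, unique, unknown or untested is made for them only; others in the source may bear on it.

The set holds four compounds built on one shared core. Compound 1 `COc1cc(-c2nn(-c3cccc(NC(=O)Nc4cc(C(F)(F)F)cc(C(F)(F)F)c4)c3)cc2-c2ccncc2)ccc1Cl` carries a 4-chloro-3-methoxyphenyl group, and compound 2 `O=C(Nc1cccc(-n2cc(-c3ccncc3)c(-c3ccc(Cl)c(O)c3)n2)c1)Nc1cc(C(F)(F)F)cc(C(F)(F)F)c1` differs from it by a single change, (hydrogen in place of methyl on an oxygen on an aromatic ring). In a functional assay on SK-MEL-5 cells (Homo sapiens) for inhibition, read by sulforhodamine B assay, with a stated time of 48 h (on this read-out higher numbers stand for lower toxicity in this test and lower numbers for higher toxicity in this test), compound 1 gives 2670 nM, and compound 2 gives 2620 nM. The step between them is a 1.0-fold lower number from compound 1 to compound 2 (0.01 log units; within the scatter), so the two numbers cannot be told apart in this test.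

Compound 3 `COc1cc(-c2nn(-c3cccc(NC(=O)Nc4ccc(Cl)c(C(F)(F)F)c4)c3)cc2-c2ccncc2)ccc1Cl` differs from compound 1 in another part of the molecule, and the difference between the two cores is not broken down here. In this assay compound 3 gives 10400 nM, the highest number among the three measured compounds, standing beyond the scatter from both compound 1 and compound 2.

Compound 4 `O=C(Nc1cccc(-n2cc(-c3ccncc3)c(-c3ccc(Cl)c(O)c3)n2)c1)Nc1ccc(Cl)c(C(F)(F)F)c1` is still to be measured in this assay. It stands to compound 3 as compound 2 stands to compound 1: the change is hydrogen in place of methyl on an oxygen on an aromatic ring, and the place is the same, on an oxygen on an aromatic ring whose other neighbours are aromatic carbon, so it is the same change. Because a 1.0-fold lower number from compound 1 to compound 2 (0.01 log units; within the scatter) lies within the scatter, the step from the methyl compound to its hydroxy counterpart is expected to be about as small here, a 1.0-fold lower number from compound 3 to compound 4 (0.02 log units; within the scatter), resting on that single precedent. On that basis compound 4 is expected to give 10000 nM, with a likely range from 5000 nM to 20000 nM.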

Compound 4, concentration lethal to 50% of the cells: 2130 nM
For compound 4 the middle estimate is 4.7-fold (0.67 log units) above the measured one; the measured number lies below the stated range.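

In this assay the change from methoxy to hydroxy gives a 4.9-fold lower number from compound 3 to compound 4 (0.69 log units; beyond the scatter), which means higher toxicity in this test for the hydroxy member of this pair, and the step does not match the one seen on the other core: the same change on two cores in this assay, a 1.0-fold lower number (0.01 log units; within the scatter) from compound 1 to compound 2 and a 4.9-fold lower number (0.69 log units; beyond the scatter) from compound 3 to compound 4, 4.8-fold (0.68 log units) apart, beyond the scatter of two such steps This shows that, across these two pairs, the size of the step from 4-chloro-3-methoxyphenyl to 4-chloro-3-hydroxyphenyl does not carry over from one core to the other, so a step that is within the scatter on one core gives no safe estimate for the same change on another. Among these compounds, it does not show why the two cores differ, and with only two pairs it gives no rule for what the same change would do on any further core.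

The compounds shown leave open how an amine or an ethoxy group in place of the hydroxy group would read on either core, and so whether the disagreement is specific to the hydroxy group. They also leave open whether a third urea partner, for instance one carrying a single trifluoromethyl group and no chlorine, would follow the first pair, the second pair, or neither.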